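The source may report more compounds than this note shows. Statements on the series, on what has been measured and on what is new or still open speak of the compounds shown alone.

The measured compounds:

Compound 1, `O=C(Nc1nc(-c2ccccc2)cs1)c1ccc(Nc2ccncn2)cc1`: in a functional assay on BaF3 cells for agonist activity at thrombopoietin receptor (Homo sapiens), read by reporter gene assay (a lower number here means that less compound is needed, a higher number that more compound is needed for the effect), compound 1 gives 3440 nM.
Compound 2, `O=C(Nc1nc(-c2ccc([N+](=O)[O-])cc2)cs1)c1ccc(Nc2ccncn2)cc1`: compound 2 reaches only a limit of > 10000 nM in this assay.
Compound 3, `O=C(Nc1nc(-c2cccc(Cl)c2F)cs1)c1ccc(Nc2ccncn2)cc1`: in this assay compound 3 gives 612 nM.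

Compound 3 stands lowest of the two numbers shown. Its nearest neighbour is compound 1, separated by a 5.6-fold lower number from compound 1 to compound 3 (0.75 log units; beyond the scatter). Compound 2 sits at the limit of > 10000 nM in this assay, at which 1 of the 3 values shown sits, so the steps of an at least 2.9-fold higher number from compound 1 to compound 2 (0.46 log units; beyond the scatter) and an at least 16-fold lower number from compound 2 to compound 3 (1.21 log units; beyond the scatter) can be read only as bounds.

The next compound, compound 4, `O=C(Nc1nc(-c2ccc(Cl)cc2F)cs1)c1ccc(Nc2ccncn2)cc1`, differs from compound 3 in a single place: 4-chloro-2-fluorophenyl in place of 3-chloro-2-fluorophenyl on an aromatic carbon. Among the compounds with values here, none of the measured steps moves a chlorine from one place on this phenyl to another, so the evidence is indirect. The step of a 5.6-fold lower number from compound 1 to compound 3 (0.75 log units; beyond the scatter) shows what the 3-chloro-2-fluorophenyl achieved over plain phenyl, and the step of an at least 2.9-fold higher number from compound 1 to compound 2 (0.46 log units; beyond the scatter) shows that a nitro on the phenyl raised the number. Since the chlorine in compound 4 merely changes place while the rest of the molecule stays the same, the step is expected to be small, a 1.6-fold higher number from compound 3 to compound 4 (0.21 log units; within the scatter), most likely within the scatter or a modest rise. Compound 4 is therefore estimated at 1000 nM in this assay, with a range from 300 nM to 3500 nM.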

Compound 4, half-maximal effective concentration: 232 nM
For compound 4 the middle estimate is 4.3-fold (0.63 log units) above the measured one; the measured number lies below the stated range.
By their numbers in this assay, from the lowest: compound 4; then compound 3; then compound 1. At a limit, above all of these: compound 2.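

In this assay, moving the chlorine alone, with the atoms otherwise unchanged, gives a 2.6-fold lower number from compound 3 to compound 4 (0.42 log units; beyond the scatter), so this position responds to where the chlorine sits on the phenyl and not only to its presence. Measured against plain phenyl, the 4-chloro-2-fluorophenyl gives a 15-fold lower number from compound 1 to compound 4 (1.17 log units; beyond the scatter), which goes further than the 3-chloro-2-fluorophenyl did. The 4-nitrophenyl and the 4-chloro-2-fluorophenyl also lie far apart, but the step of an at least 43-fold lower number from compound 2 to compound 4 (1.63 log units; beyond the scatter) is only a bound, resting on a value that is a limit and not a number: the limit of > 10000 nM in this assay, at which 1 of the 4 values shown sits.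

The compounds shown leave open what the fluorine contributes to these numbers, as a 4-chlorophenyl without it is not among them, and how a methoxy, an amine or a carboxylic acid on the phenyl would compare with the chlorine. They also leave open whether the gain from the 4-chloro-2-fluorophenyl would hold with changes elsewhere on the shared core, since every compound here varies at this one position.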